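A few compounds are considered here, and "the series" means these few. Any claim that something is new, unique, unknown or untested is made for them only; others in the source may bear on it.

Measured compounds:
Compound 1, `COc1cc(CC(O)(COCc2ccccc2)COCc2ccccc2)nc(OC)n1`, in a functional assay on SW-620 cells (Homo sapiens) for antiproliferative activity, read by MTT assay, with a stated time of 72 h (on this read-out higher numbers stand for weaker inhibition and lower numbers for stronger inhibition), gives a limit of the assay, > 100000 nM.
Compound 2, `COc1nc(CC(O)(COCc2ccccc2)COCc2ccccc2)c(C)c(OC)n1`, in this assay gives 3500 nM.
Compound 3, `COCn1c(CC(COCc2ccccc2)COCc2ccccc2)cc(=O)[nH]c1=O`, in this assay gives a limit of the assay, > 100000 nM.

The change from compound 1 to compound 2 is methyl in place of hydrogen on an aromatic carbon, and it produced an at least 28-fold lower number from compound 1 to compound 2 (1.45 log units; beyond the scatter). Compound 4, `COCn1c(CC(COCc2ccccc2)COCc2ccccc2)c(C)c(=O)[nH]c1=O`, carries the same kind of change on the core of compound 3, (methyl in place of hydrogen on an aromatic carbon); the surroundings of the place differ, since here the methyl sits ortho to a group of 1 heavy atom, meta to a methoxymethyl group and para to a group of 1 heavy atom, whereas in compound 2 it sits ortho and para to methoxy groups. The difference between the two cores is not broken down here. The value of compound 3 is a limit, as noted in the limit of > 100000 nM in this assay, at which 2 of the 3 values shown sit, so the starting point is uncertain. By analogy with compound 2, the step from compound 3 to compound 4 in this assay is expected to be about an at least 10-fold lower number from compound 3 to compound 4 (1.00 log units; beyond the scatter). Compound 4 is therefore estimated at 10000 nM, likely between 2000 nM and 100000 nM.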

Compound 4, half-maximal inhibitory concentration: 72100 nM
The estimate for compound 4 lay 7.2-fold (0.86 log units) below the measured number; the range from low to high includes it.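

In this assay, methyl in place of hydrogen on an aromatic carbon of the core of compound 3 gives an at least 1.3-fold lower number from compound 3 to compound 4 (0.14 log units; that floor lies within the scatter). Compound 3 gives only a limit of the assay, so this step has a floor and no true size, and the same holds for the earlier step from compound 1: the limit of > 100000 nM in this assay, at which 2 of the 4 values shown sit. The data therefore show neither that the size of the change carries over from one core to the other nor that it fails to: the same change on two cores in this assay, an at least 28-fold lower number (1.45 log units; beyond the scatter) from compound 1 to compound 2 and an at least 1.3-fold lower number (0.14 log units; that floor lies within the scatter) from compound 3 to compound 4; the limit leaves it open whether they differ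

The compounds shown leave open what an ethyl group or a chlorine would do on that aromatic carbon. They also leave open how far the methyl step reaches on either core once its starting compound has a measured number.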